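Aryl amide changes in a cytotoxic series

A few compounds are considered here, and "the series" means these few. Any claim that something is new, unique, unknown or untested is made for them only; others in the source may bear on it.

- compound 1 `O=C(CN1CCN(c2nnc(Cc3ccncc3)c3ccccc23)CC1)Nc1ccc(Br)cc1` gives 2710 nM
- compound 2 `O=C(CN1CCN(c2nnc(Cc3ccncc3)c3ccccc23)CC1)Nc1cccc(F)c1` gives 4600 nM

Both values come from a functional assay on A549 cells (Homo sapiens) for cytotoxicity, read by MTT assay, with a stated time of 72 h; on this read-out higher numbers stand for weaker inhibition and lower numbers for stronger inhibition. Compound 2 stands level with compound 1 within the scatter, and no distinct rank can be given. Compound 3 `O=C(CN1CCN(c2nnc(Cc3ccncc3)c3ccccc23)CC1)Nc1ccc(F)c(Cl)c1` carries 3-chloro-4-fluorophenyl in place of 3-fluorophenyl on an amide-type nitrogen, again on an amide-type nitrogen. Going by the values given here, the one measured change at that place, a 1.7-fold higher number from compound 1 to compound 2 (0.23 log units; within the scatter), gives no sign of a large response, so no step beyond the scatter is expected in this assay. The expected step is a 1.3-fold lower number from compound 2 to compound 3 (0.12 log units; within the scatter). Compound 3 is estimated at 3500 nM, with an expected range of 1500 nM to 8000 nM.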

Compound 3, half-maximal inhibitory concentration: 12300 nM
Compound 3: middle estimate off by 3.5-fold (0.55 log units), on the low side; the whole stated range lies below it.
By their numbers in this assay, from the lowest: compounds 1 and 2 (each within the scatter of the next); then compound 3.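

Within this assay, the aryl group on the amide-type nitrogen can shift the number beyond the scatter, which the first pair of compounds did not show. Replacing 3-fluorophenyl or 4-bromophenyl with 3-chloro-4-fluorophenyl gives a 2.7-fold higher number from compound 2 to compound 3 (0.43 log units; beyond the scatter) and a 4.5-fold higher number from compound 1 to compound 3 (0.66 log units; beyond the scatter) and so moves toward weaker inhibition. No available evidence accounts for this shift.

Going by these compounds, it remains open whether the chlorine or the fluorine of 3-chloro-4-fluorophenyl drives the step. On these data alone, the response to a phenyl ring carrying an amine or a carboxylic acid also remains open.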